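Amide series: methoxy for dimethylamino at the para position

The source may report more compounds than this note shows. Statements on the series, on what has been measured and on what is new or still open speak of the compounds shown alone.

Two compounds of the series carry a measurement. Compound 1 `COc1cc(C(=O)Nc2ccc(Cl)c(-c3nc4ccccc4[nH]3)c2)cc(OC)c1OC` is tested in a functional assay on Shh Light II cells for inhibition of Sonic hedgehog protein (Mus musculus), read by reporter gene assay, with a stated time of 48 h, in the presence of a further agent that is not named here (a higher number here means a weaker inhibitor, a lower number a stronger inhibitor), and gives 79.8 nM. Within the data shown here, compound 2 `CN(C)c1ccc(C(=O)Nc2ccc(Cl)c(-c3nc4ccccc4[nH]3)c2)cc1` differs from it in the group on the acyl side of the amide, and in this assay compound 2 gives 190 nM, the highest of the two numbers on hand; the only neighbour, compound 1, lies lower by a margin beyond the usual scatter. Among the measured compounds shown here, no two measured compounds differ in a single place, so no single step can be read from the numbers.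

Compound 3 `COc1ccc(C(=O)Nc2ccc(Cl)c(-c3nc4ccccc4[nH]3)c2)cc1` is the next member and is not yet measured. It differs from compound 2 in one place only: methoxy in place of dimethylamino on an aromatic carbon. Both groups that change hands sit on an aromatic carbon, para to a large group, and both bring one hydrogen-bond acceptor and no donor.

For the measured compounds named here, with no comparable step in the data, the step of a 1.3-fold lower number from compound 2 to compound 3 (0.10 log units; within the scatter) is expected to stay within the scatter, with at most a slight drift toward a lower number. Compound 3 is therefore expected to give about 150 nM, with a range from 50 nM to 450 nM.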

Compound 3, half-maximal inhibitory concentration: 117 nM
Compound 3: the middle estimate sits 1.3-fold (0.11 log units) above what was measured, within the range that was stated.
By their numbers in this assay, from the lowest: compounds 1, 3 and 2 (each within the scatter of the next, the first and the last beyond it).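

In this assay, methoxy in place of dimethylamino on the aromatic carbon para to a large group gives a 1.6-fold lower number from compound 2 to compound 3 (0.21 log units; within the scatter), the first single-place step available in the series. This position therefore accepts either group with no difference that can be told from repeat scatter, so for this pair the swap of the nitrogen-linked group for the oxygen-linked one, with its smaller heavy-atom count and the same count of donors and acceptors, leaves the number effectively unchanged. No measurement on hand bears on why the two groups read alike.

Among these compounds, the pair covers only two groups at this position, both with an acceptor atom attached directly to the aromatic carbon, so it cannot tell whether that feature matters or whether plain hydrogen, a chlorine or a methyl group would read the same. On these data alone, it is also open how far the tolerance extends, for instance to a longer chain such as butoxy or to a carboxylic acid on the same carbon, and a single step within the scatter sets no trend for the series.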